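The compounds below may be only part of what the source reports. "The series", "measured", "known", "first", "only" and "open" are said of these compounds alone.

Measured so far:
- compound 1, `COc1ccc(N2CCN(C(=O)Cn3cnc([N+](=O)[O-])n3)CC2)cc1`: 133000 nM
- compound 2, `Cc1ccc(N2CCN(CC(=O)N3CCN(c4ccc(C)cc4)CC3)CC2)cc1`: 213000 nM

In an ADME assay on L6 cells (Rattus norvegicus) for cytotoxicity (a higher number here means a weaker inhibitor, a lower number a stronger inhibitor), compound 1 gives 133000 nM and compound 2 gives 213000 nM; the gap between these two numbers lies within the usual scatter of repeated measurements, so on this assay the two compounds cannot be told apart. Both sit at the weak end of what this assay can resolve. Within the data shown here, no step between two measured compounds that differ in one place is available, so there is no measured step from which the size of a single substituent change can be read.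

Compound 3, `O=C(Cn1cnc([N+](=O)[O-])n1)N1CCN(c2ccc(Cl)c(Cl)c2)CC1`, is not yet measured in this assay. It differs from compound 1 in one place:

3,4-dichlorophenyl in place of 4-methoxyphenyl on an amine nitrogen in a ring

Among the measured compounds shown here, with no comparable measured step in hand, the expectation rests on the structural change alone. A moderate step toward a lower number, that is toward stronger inhibition, is expected, beyond the scatter but not by a wide margin.

Compound 3 is estimated at 60000 nM in this assay, within a range from 15000 nM to 200000 nM, which corresponds to an expected step of a 2.2-fold lower number from compound 1 to compound 3 (0.35 log units; beyond the scatter).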

Compound 3, half-maximal inhibitory concentration: 108000 nM
Estimate against measurement, compound 3: 1.8-fold (0.26 log units) below; low and high end bracket the measured number.
By their numbers in this assay, from the lowest: compounds 3, 1 and 2 (each within the scatter of the next).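

Among these compounds, the step of a 1.2-fold lower number from compound 1 to compound 3 (0.09 log units; within the scatter) in this assay is the only single-place comparison on hand, and it gives this position its first reading. With the shared core held constant, 3,4-dichlorophenyl in place of 4-methoxyphenyl on an amine nitrogen in a ring produces no difference that can be resolved, even though the entering group has no hydrogen-bond acceptor and carries chlorine instead of oxygen, so this one exchange gives no sign that the read-out depends on which of these two substituted phenyl groups occupies the position. No measurement on hand speaks to what lies behind this result.

Both groups compared are substituted phenyl rings of equal heavy-atom count, so the compounds shown leave open whether a clearly different group at this position, such as a carboxylic acid or a primary amine on the phenyl ring, or a longer chain between the ring nitrogen and the phenyl ring, would move the number beyond the scatter. They also leave open whether the same exchange would read the same on a core other than that of compound 1.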